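This account rests on a few compounds, and the source may have more. Where it says the series, first, only, none or still open, it means among the compounds named here.

Measured so far in a physicochemical assay for lipophilicity, read by HPLC; a lower number here means a more polar compound, a higher number a more lipophilic compound:
- compound 1 `Cc1ccsc1C(=CCCN(C)C(CCO)C(=O)NCc1ccc(F)cc1F)c1sccc1C` gives 6.37
- compound 2 `Cc1ccsc1C(=CCCN(C)C(CCN)C(=O)NCc1ccccc1Cl)c1sccc1C` gives 6.11
- compound 3 `Cc1ccsc1C(=CCCN(C)C(CC(C)O)C(=O)NCc1ccccc1Cl)c1sccc1C` gives 5.95; 5.67 (2 entries)

Compound 1 (6.37) and compound 2 (6.11) lie within the usual scatter of each other, so no order can be drawn between them. Compound 3 has two entries and no single number, and its readings (the several entries of compound 3 in this assay, 5.95; 5.67 (2 entries)) show how far repeats of one compound can lie apart. Among the measured compounds shown here, no two measured compounds differ in one place only, which leaves the data without a direct guide to the size of the next step.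

Compound 4 (`Cc1ccc(CNC(=O)C(CCO)N(C)CCC=C(c2sccc2C)c2sccc2C)cc1`) has not yet been measured. It keeps the core of compound 1 and carries 4-methylphenyl in place of 2,4-difluorophenyl on a saturated chain carbon bound to an amide-type nitrogen. In this assay a small upward move is expected, with no step beyond the scatter. The estimated change is a number 0.13 log units higher from compound 1 to compound 4 (within the scatter) and no more. Compound 4 is expected at 6.5 (estimated range 6.1 to 6.9).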

Compound 4, partition coefficient: 6.2
For compound 4 the middle estimate is 0.30 log units above the measured one; measured number inside the range.
By their numbers in this assay, from the lowest: compounds 2, 4 and 1 (each within the scatter of the next).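

The series now holds its first comparison at a single place: in this assay, 4-methylphenyl in place of 2,4-difluorophenyl on a saturated chain carbon bound to an amide-type nitrogen gives a number 0.17 log units lower from compound 1 to compound 4 (within the scatter). At this position, then, removing both fluorine atoms and introducing a methyl group leaves no difference in this assay that can be told from the scatter. The step is no wider than the spread of repeated readings of a single compound: the several entries of compound 3 in this assay, 5.95; 5.67 (2 entries)

One exchange cannot show whether a phenyl carrying an amine or a carboxylic acid, or a longer chain in place of the 4-methylbenzyl group, would move the reading beyond the scatter. The compounds shown also leave open what a single fluorine or the methyl group would do alone at this place.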